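This account rests on a few compounds, and the source may have more. Where it says the series, first, only, none or still open, it means among the compounds named here.

Compounds measured:
Compound 1, `O=C(CCCc1ccccc1)Nc1nc2ccsc2c(=O)s1`, in an assay on membranes from brain for displacement of a labelled ligand from adenosine receptor A1 (Rattus norvegicus), read by scintillation counting, with a stated time of 90 min (on this read-out lower numbers stand for stronger inhibition and higher numbers for weaker inhibition), gives >= 10000 nM, a limit of the assay rather than a number.
Compound 2, `O=C(CCc1ccccc1)Nc1nc2ccccc2c(=O)s1`, in this assay gives 422 nM.

Compound 2 thus stands as the only numeric result shown; the result for compound 1 sits at the limit of >= 10000 nM in this assay, at which 1 of the 2 values shown sits. Compound 3, `COc1cccc(CCC(=O)Nc2nc3ccccc3c(=O)s2)c1`, differs from compound 2 by methoxy in place of hydrogen on an aromatic carbon. Among the compounds with values here, no measured pair mirrors this change, so the author expects a 1.1-fold lower number from compound 2 to compound 3 (0.02 log units; within the scatter) to fall within the usual scatter, with no firm direction. On that basis compound 3 is estimated at 400 nM, within a range from 150 nM to 1200 nM.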

Compound 3, inhibition constant: 367 nM
Beside the measured number, compound 3's estimate is 1.1-fold (0.04 log units) above it; low and high end bracket the measured number.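

Methoxy in place of hydrogen on this six-membered aromatic ring, meta to a large group, gives the only step shown between compounds that differ in one place. In this assay, the change gives a 1.1-fold lower number from compound 2 to compound 3 (0.06 log units; within the scatter), so the number stays within the usual scatter and this position accepts methoxy without a readable change. Nothing shown gives a reason for this outcome.

Going by these compounds, it remains open whether an amine or a carboxylic acid at this position would also leave the number within the scatter. On these data alone, it is equally open whether methoxy on another carbon of the ring would do so.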